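The source may report more compounds than this note shows. Statements on the series, on what has been measured and on what is new or still open speak of the compounds shown alone.

Measured in an ADME assay on L6 cells (Rattus norvegicus) for cytotoxicity, with a stated time of 72 h; a higher number here means a weaker inhibitor, a lower number a stronger inhibitor:
- compound 1 `CCN(CC)CC(=O)OC1CC2(N(C)C)CC(c3ccccc3)C1C(c1ccccc1)C2`: 30100 nM
- compound 2 `CC(C)(C)C(=O)OC1CC2(N3CCCC3)CC(c3ccccc3)C1C(c1ccccc1)C2`: 7620 nM
- compound 3 `CCN(CC)CC(=O)OC1CC2(N3CCCC3)CC(c3ccccc3)C1C(c1ccccc1)C2`: 49000 nM

Compound 3 cannot be told apart from compound 1, and its number lies above that of compound 2. Next is compound 4 `O=C(CN1CCCC1)OC1CC2(N3CCCC3)CC(c3ccccc3)C1C(c1ccccc1)C2`, with pyrrolidin-1-yl in place of diethylamino on a saturated chain carbon bound to a carbonyl carbon. Within the data shown here, the nearest precedent has pyrrolidin-1-yl replacing dimethylamino on a saturated ring carbon, a 1.6-fold higher number from compound 1 to compound 3 (0.21 log units; within the scatter). The modest step, a 6.4-fold higher number from compound 2 to compound 3 (0.81 log units; beyond the scatter), replaced tert-butyl with (diethylamino)methyl, whereas compound 4 keeps a comparable (pyrrolidin-1-yl)methyl there. No change beyond the scatter is therefore expected in this assay, and the estimated step is a 1.2-fold lower number from compound 3 to compound 4 (0.09 log units; within the scatter). For compound 4 the expected value is 40000 nM, with an estimated range of 18000 nM to 85000 nM.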

Compound 4, half-maximal inhibitory concentration: 42900 nM
Compound 4: middle estimate off by 1.1-fold (0.03 log units), on the low side, and the stated range covers the measured number.
By their numbers in this assay, from the lowest: compound 2; then compounds 1, 4 and 3 (each within the scatter of the next).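

In this assay, pyrrolidin-1-yl in place of diethylamino on a saturated chain carbon bound to a carbonyl carbon gives a 1.1-fold lower number from compound 3 to compound 4 (0.06 log units; within the scatter), so a ring amine and an open-chain amine cannot be told apart at this position. With (pyrrolidin-1-yl)methyl in place of tert-butyl on a carbonyl carbon, the step is a 5.6-fold higher number from compound 2 to compound 4 (0.75 log units; beyond the scatter), so the rise seen with (diethylamino)methyl recurs with a second amine. No supporting data bear on the reason for either step.

Still open, on these data alone, is whether a morpholine at this chain carbon would stay within the scatter of compound 4. Also open, as far as these compounds go, is what a carboxylic acid in place of the amine would give.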